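The compounds below may be only part of what the source reports. "The series", "measured", "known", "first", "only" and "open" are said of these compounds alone.

Compound 2 `CCc1nc2nc(-c3ccccc3)cc(C(F)(F)F)c2c(=O)n1Cc1cn(CCC(F)(F)C(F)(F)C(F)(F)C(F)(F)C(F)(F)C(F)(F)F)nn1` was tested in a functional assay on COLO 205 cells (Homo sapiens) for cytotoxicity, read by MTT assay, with a stated time of 24 h (a higher number here means a weaker inhibitor, a lower number a stronger inhibitor), where compound 2 gives > 200 ug/mL; this is a limit of the assay and not a number, so compound 2 stands at the limit of > 200 ug/mL in this assay, at which 1 of the 2 values shown sits. Compound 1 `O=c1c2c(C(F)(F)F)cc(-c3ccccc3)nc2ncn1Cc1cn(CCC(F)(F)C(F)(F)C(F)(F)C(F)(F)C(F)(F)C(F)(F)C(F)(F)C(F)(F)F)nn1` gives 163 ug/mL in this assay. Compound 3 `CCc1nc2nc(-c3ccccc3)cc(C(F)(F)F)c2c(=O)n1Cc1cn(CCC(F)(F)C(F)(F)C(F)(F)C(F)(F)C(F)(F)C(F)(F)C(F)(F)C(F)(F)F)nn1` has not yet been measured in this assay. Compound 3 differs from compound 2 in one place, (1,1,2,2,2-pentafluoroethyl in place of fluoro on a saturated chain carbon bound to two fluorine atoms and a saturated chain carbon), that is, 1,1,2,2,2-pentafluoroethyl in place of fluoro on a saturated chain carbon bound to two fluorine atoms and a saturated chain carbon. Among the measured compounds shown here, no single-change step between measured compounds exists here, and compound 1 and compound 2 differ from each other in more than one place, so their two values show only that both sit at the weak end of this assay. The step expected is an at least 1.1-fold lower number from compound 2 to compound 3 (0.04 log units; that floor lies within the scatter), none beyond the scatter. Compound 3 is estimated at 180 ug/mL, with a range from 90 ug/mL to 320 ug/mL.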

Compound 3, half-maximal inhibitory concentration: > 200 ug/mL
Compound 3 gave a limit, no number (the forecaster's own chance of this, stated with the estimate: 55%); middle value at least 1.1-fold (0.04 log units) away from the limit.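

Compound 3 gives a limit in this assay, not a number, and so does compound 2, so the step for 1,1,2,2,2-pentafluoroethyl in place of fluoro on this saturated chain carbon cannot be read: the limit of > 200 ug/mL in this assay, at which 2 of the 3 values shown sit.

Among the compounds shown here, the one step that can be read is ethyl in place of hydrogen on an aromatic carbon, which gives an at least 1.2-fold higher number from compound 1 to compound 3 (0.08 log units; that floor lies within the scatter). The true size of this step may be larger, but its floor alone does not place it beyond the scatter.

On these data alone, it remains open whether ethyl in place of hydrogen truly moves the value in this assay. As far as these compounds go, it is also open whether a shorter fluorinated chain, or an amine or a carboxylic acid at the end of the chain, would give a number rather than a limit.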